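The compounds below may be only part of what the source reports. "The series", "measured", "known", "first", "only" and "open" are said of these compounds alone.

Compound 1 `Cc1cnnc(N2CCN(C(=O)Nc3ccc(C(C)C)cc3)CC2)c1` and compound 2 `Cc1cnnc(N2CCN(C(=O)Nc3ccc(OC(F)(F)F)cc3)CC2)c1` share the same core and differ only at one aromatic carbon. In an assay on HEK293 cells for inhibition of transient receptor potential cation channel subfamily V member 1 (Homo sapiens), read by FLIPR, at pH 5.5 (on this read-out lower numbers stand for stronger inhibition and higher numbers for weaker inhibition), compound 1 gives 20300 nM. For compound 2 this assay reports only a limit, > 10000 nM, so its standing is known only as that limit. The step that the limit leaves unreadable from compound 1 to compound 2 therefore cannot be read in size, as the limit of > 10000 nM in this assay, at which 1 of the 2 values shown sits, records. Compound 3 `O=C(Nc1ccc(OC(F)(F)F)cc1)N1CCN(c2nncc3ccccc23)CC1` keeps the trifluoromethoxy group of compound 2 and changes the other end of the core: a group of 10 heavy atoms (8 carbon, 2 nitrogen; one six-membered aromatic ring of carbon only, one six-membered aromatic ring with 2 hetero atoms) in place of a group of 7 heavy atoms (5 carbon, 2 nitrogen; one six-membered aromatic ring with 2 hetero atoms), on an amine nitrogen in a ring. Among the measured compounds shown here, no measured step touches this position, so the only guide is that both measured compounds sit at the weak end of this assay, one of them at the limit. On that basis the step from compound 2 to compound 3 is expected to be a step that the limit leaves unreadable from compound 2 to compound 3. Compound 3 is thus estimated at 15000 nM, within 3000 nM to 60000 nM.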

Compound 3, half-maximal inhibitory concentration: > 10000 nM
Compound 3 gave a limit, no number; the forecaster's own chance of this, stated with the estimate: 45%; the middle value is on the limit's open side.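

Among the compounds shown here, compound 3, like compound 2, gives only a limit in this assay, so no step between compound 2 and compound 3 can be read: the limit of > 10000 nM in this assay, at which 2 of the 3 values shown sit. The compounds shown leave open how strongly compound 2 and compound 3 inhibit the channel, and whether exchanging 5-methylpyridazin-3-yl for the larger group changes inhibition at all.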